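Compound 3 and the step to its 2-fluorophenyl analogue

The source may hold more compounds than are shown below. What is called first, only, known or untested is meant among the compounds shown, and "the series" means these compounds.

Compound 1 `C=CS(=O)(=O)N1CCN(c2ncnc3sc(-c4ccc(N5CCN(C)CC5)cc4)cc23)CC1`: 7550 nM
Compound 2 `CN1CCN(c2ccc(-c3cc4c(N5CCN(S(=O)(=O)N6CCCCC6)CC5)ncnc4s3)cc2)CC1`: 8130 nM
Compound 3 `COc1ccc(NC(=O)N2CCN(c3ncnc4sc(-c5ccc(N6CCN(C)CC6)cc5)cc34)CC2)cc1`: 20900 nM

All three values come from a functional assay on MDA-MB-231 cells (Homo sapiens) for antiproliferative activity, read by MTT assay, with a stated time of 48 h; on this read-out lower numbers stand for stronger inhibition and higher numbers for weaker inhibition. Compound 3 has the highest number of the three and is therefore the weakest inhibitor among them. Its distance from the other two is modest, with a 2.8-fold higher number from compound 1 to compound 3 (0.44 log units; beyond the scatter) and a 2.6-fold higher number from compound 2 to compound 3 (0.41 log units; beyond the scatter), whereas a 1.1-fold higher number from compound 1 to compound 2 (0.03 log units; within the scatter) stays within the scatter.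

Compound 4 `CN1CCN(c2ccc(-c3cc4c(N5CCN(C(=O)Nc6ccccc6F)CC5)ncnc4s3)cc2)CC1` differs from compound 3 only in the aryl group of the carbamoyl unit: 2-fluorophenyl in place of 4-methoxyphenyl on an amide-type nitrogen. In words, this is 2-fluorophenyl in place of 4-methoxyphenyl on an amide-type nitrogen. Among the measured compounds shown here, no measured step makes this exchange on its own. The two steps into compound 3 replace the entire sulfonyl group on the ring amine nitrogen, so they bear on it only indirectly and offer a rough upper guide to its size. A step no larger than those, probably within the scatter, is therefore expected in this assay. A slight lean towards a lower number is expected, since compound 3 at 20900 nM sits at the top of this small set. The estimated step is a 1.4-fold lower number from compound 3 to compound 4 (0.14 log units; within the scatter). The expected value for compound 4 is 15000 nM, with an estimated range of 6000 nM to 40000 nM.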

Compound 4, half-maximal inhibitory concentration: 10300 nM
For compound 4 the middle estimate is 1.5-fold (0.16 log units) above the measured one, and the stated range covers the measured number.
By their numbers in this assay, from the lowest: compounds 1, 2 and 4 (each within the scatter of the next); then compound 3.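

In this assay, this change isolates the aryl group on the carbamoyl unit, leaving the rest of the molecule untouched, and the exchange of 4-methoxyphenyl for 2-fluorophenyl on the amide-type nitrogen gives a 2.0-fold lower number from compound 3 to compound 4 (0.31 log units; beyond the scatter) and so lies beyond the scatter. The earlier steps shown here replaced the whole group on the ring amine nitrogen, so they could not show that the aryl group alone can move the number; the high value of compound 3 therefore does not belong to the carbamoyl link as such, since the steps of a 1.3-fold higher number from compound 2 to compound 4 (0.10 log units; within the scatter) and a 1.4-fold higher number from compound 1 to compound 4 (0.13 log units; within the scatter) both stay within the scatter of the two sulfonyl compounds. Nothing measured here accounts for the effect of the aryl exchange.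

The exchange alters both the substituent and its place on the ring at once, so the two contributions remain unseparated, and 4-fluorophenyl or 2-methoxyphenyl on the same nitrogen would pull them apart. Going by these compounds, how plain phenyl or a cyclohexyl group in this place would compare also remains open.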